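Hydroxyethylamine in Place of Piperidine on the Shared Core

A few compounds are considered here, and "the series" means these few. Any claim that something is new, unique, unknown or untested is made for them only; others in the source may bear on it.

Compound 1, `COc1ccc(Nc2cc(C)nc(SCc3nc4ccccc4[nH]3)n2)cc1`, gives 67400 nM in a functional assay on PC-3 cells (Homo sapiens) for cytotoxicity, read by MTT assay, with a stated time of 72 h; on this read-out higher numbers stand for weaker inhibition and lower numbers for stronger inhibition. Compound 2, `Cc1cc(Nc2ccc(Cl)cc2)nc(SCc2nc3ccccc3[nH]2)n1`, gives 36000 nM. Compound 3, `Cc1cc(N2CCCCC2)nc(SCc2nc3ccccc3[nH]2)n1`, is recorded only as a limit, > 100000 nM.

Compound 3 therefore sits at the weak edge of the measured set, at the limit of > 100000 nM in this assay, at which 1 of the 3 values shown sits. Compound 4, `Cc1cc(NCCO)nc(SCc2nc3ccccc3[nH]2)n1`, differs from compound 3 in one place: (2-hydroxyethyl)amino in place of piperidin-1-yl on an aromatic carbon. Going by the values given here, two measured steps bear on this position, both replacing an arylamino group with piperidin-1-yl: an at least 1.4-fold higher number from compound 1 to compound 3 (0.17 log units; that floor lies within the scatter) and an at least 2.7-fold higher number from compound 2 to compound 3 (0.44 log units; beyond the scatter). Restoring an amino group, here a small (2-hydroxyethyl)amino chain, is expected to reverse part of that loss, though no open-chain amine has been measured. Compound 4 is expected to give 70000 nM, within 20000 nM to 200000 nM. The expected step is an at least 1.4-fold lower number from compound 3 to compound 4 (0.15 log units; that floor lies within the scatter), with a fair chance that only a limit is returned.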

Compound 4, half-maximal inhibitory concentration: > 100000 nM
Compound 4 ended at the assay's limit; the forecaster's own chance of this, stated with the estimate: 40%; middle value at least 1.4-fold (0.15 log units) from the limit.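

Compound 3 and compound 4 both end at a limit in this assay, so the step between them cannot be read: the limit of > 100000 nM in this assay, at which 2 of the 4 values shown sit. Against the compounds with an aryl group on the nitrogen, placing 2-hydroxyethyl there gives an at least 2.7-fold higher number from compound 2 to compound 4 (0.44 log units; beyond the scatter) and an at least 1.4-fold higher number from compound 1 to compound 4 (0.17 log units; that floor lies within the scatter). Only compound 1 and compound 2 return a number rather than a limit, so the open chain did not restore one.

Still open, as far as these compounds go, is whether a cyclohexylamino or a benzylamino group would return a number, and so whether an aromatic ring directly on that nitrogen matters.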